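Trifluoromethyl ketone in place of the pyridyl ester

A few compounds are considered here, and "the series" means these few. Any claim that something is new, unique, unknown or untested is made for them only; others in the source may bear on it.

Three compounds of the shared core have numbers in an assay for inhibition of Fatty-acid amide hydrolase 1 (Rattus norvegicus); a lower number here means a stronger inhibitor, a higher number a weaker inhibitor. Compound 1 `COC(=O)c1cc(-c2cnc(C(=O)CCc3ccc(-c4ccccc4)cc3)o2)ccn1` gives 1.5 nM. Compound 2 `N#Cc1cccc(-c2cnc(C(=O)CCc3ccc(COc4ccccc4)cc3)o2)n1` gives 0.56 nM, and compound 3 `CN1CCN(Cc2ccc(-c3ccc(CCC(=O)c4ncc(-c5cccc(C(=O)O)n5)o4)cc3)cc2)CC1` gives 1200 nM. On these three numbers compound 1 stands second highest: compound 2 sits nearer with a lower number beyond the scatter, while compound 3 sits far above it, also beyond the scatter. Going by the values given here, no single-change step between any two of the measured compounds is available, so no measured step size can guide the next comparison directly.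

Compound 4 `O=C(CCc1ccc(-c2ccccc2)cc1)c1ncc(C(=O)C(F)(F)F)o1` has not been measured in this assay. It differs from compound 1 in one place: (trifluoromethyl)carbonyl in place of 2-(methoxycarbonyl)pyridin-4-yl on an aromatic carbon. The large aromatic group is exchanged for a small (trifluoromethyl)carbonyl group, while the rest of compound 1, including the biphenyl chain, is kept.

Among the compounds with values here, with no measured step for this change, the expectation rests on compound 1 alone. A modest rise in the number is estimated for compound 4, so the step of a 3.3-fold higher number from compound 1 to compound 4 (0.52 log units; beyond the scatter) is expected to lie a little beyond the scatter but not far. Compound 4 is therefore estimated at 5 nM, within a range from 1.2 nM to 20 nM.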

Compound 4, inhibition constant: 8 nM
Estimate against measurement, compound 4: 1.6-fold (0.20 log units) below; low and high end bracket the measured number.
By their numbers in this assay, from the lowest: compound 2; then compound 1; then compound 4; then compound 3.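

In this assay, going by these compounds alone, exchanging 2-(methoxycarbonyl)pyridin-4-yl for (trifluoromethyl)carbonyl on the aromatic carbon next to the ring oxygen gives the first single-place step, a 5.3-fold higher number from compound 1 to compound 4 (0.73 log units; beyond the scatter), and it is a modest one. With the biphenyl chain kept, compound 4 still gives 8 nM with no ring at this position, so on this pair a six-membered aromatic ring is not needed there for a low nanomolar number, although the ring, its nitrogen and the methyl ester all leave together and the step cannot be divided among them. No measurement is available that bears on the reason for this step.

On these data alone, it remains open how a small group without a ring but without fluorine, such as an acetyl group or a primary amide, would compare on the same carbon with the biphenyl chain kept. Also open, as far as these compounds go, is whether the same exchange would give a step of similar size on the chain of compound 2.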